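The source may hold more compounds than are shown below. What is called first, only, known or untested is meant among the compounds shown, and "the series" means these compounds.

Measured compounds, values from a functional assay on HCC15 cells (Homo sapiens) for inhibition; a higher number here means a weaker inhibitor of growth, a lower number a stronger inhibitor of growth:
- compound 1 `COc1ccc(-n2cnnc2-c2cc(OC)c(OC)c(OC)c2)cc1`: 1700 nM
- compound 2 `COc1cc(-c2nncn2-c2ccc(N(C)C)cc2)cc(OC)c1OC`: 60.3 nM

Compound 1 holds the higher of the two numbers, so it is the weaker growth inhibitor of the pair in this assay, and compound 2 is its nearest neighbour. Compound 3 `COc1ccc(-n2cnnc2-c2cc(OC)c(OC)c(OC)c2)cc1O` is not yet measured. It differs from compound 1 by one change: hydroxy in place of hydrogen on an aromatic carbon. This is hydroxy in place of hydrogen on an aromatic carbon, ortho to a methoxy group and meta to a large group.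

Among the measured compounds shown here, only one measured step bears on this change, and only indirectly. The step of a 28-fold lower number from compound 1 to compound 2 (1.45 log units; beyond the scatter) is large and lies beyond the scatter, but it replaces methoxy with dimethylamino rather than replacing a hydrogen. It shows that the number can move strongly with a change on the aromatic ring that carries that methoxy group. It does not fix the direction for hydroxy, so a lower number is expected only tentatively, with a step smaller than that measured one and a wide margin. The expected change is a 6.8-fold lower number from compound 1 to compound 3 (0.83 log units; beyond the scatter). For compound 3 the estimated value is 250 nM, with an expected range from 30 nM to 2000 nM.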

Compound 3, concentration for 50% growth inhibition: 631 nM
Compound 3: middle estimate off by 2.5-fold (0.40 log units), on the low side; the range from low to high includes it.
By their numbers in this assay, from the lowest: compound 2; then compound 3; then compound 1.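

In this assay, among the compounds shown here, a 2.7-fold lower number from compound 1 to compound 3 (0.43 log units; beyond the scatter) gives the first direct reading at this position: hydroxy in place of hydrogen on an aromatic carbon, ortho to a methoxy group, lowers the number by a modest step that still lies beyond the scatter. The earlier pair covered only a replacement of the methoxy group itself, a 28-fold lower number from compound 1 to compound 2 (1.45 log units; beyond the scatter), so the series now also holds a change at a second place on that aromatic ring, read against the same reference, compound 1. Nothing available accounts for the lower number of compound 3.

Compound 3 keeps the methoxy group, so the compounds shown cannot separate what hydroxy does alone from what it does with that methoxy group present. On these data alone, it also remains open whether an amine, a fluorine atom or a longer ether chain at this same place would lower the number as hydroxy does, or whether any such group combined with the dimethylamino group of compound 2 would move the number further.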